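This account rests on a few compounds, and the source may have more. Where it says the series, first, only, none or still open, it means among the compounds named here.

Measured compounds:
Compound 1 `CC(C)(C)c1ccc(C(=O)N2CCC3(CC2)C(=O)N(CC(=O)NCCCN)CN3c2ccccc2)cc1` gives 4200 nM in an assay on HEK293 cells for displacement of a labelled ligand from NPC1-like intracellular cholesterol transporter 1 (Homo sapiens); a higher number here means a weaker inhibitor, a lower number a stronger inhibitor
Compound 2 `COC(=O)CCNC(=O)CN1CN(c2ccccc2)C2(CCN(C(=O)c3ccc(C(C)(C)C)cc3)CC2)C1=O` gives "not determined" (no result reported)

Going by the values given here, compound 2 therefore stands nowhere on the scale of this assay: no number exists for it, so no step to it can be sized. Compound 3 `CC(C)(C)c1ccc(C(=O)N2CCC3(CC2)C(=O)N(CC(=O)N2CCC(CCO)CC2)CN3c2ccccc2)cc1` differs from compound 2 by one change (4-(2-hydroxyethyl)piperidin-1-yl in place of (2-(methoxycarbonyl)ethyl)amino on a carbonyl carbon). Among the compounds with values here, with no measured pair sharing this change, the size and direction of the step in this assay cannot be taken from the data; the only anchor is compound 1 at 4200 nM. Compound 3 is expected to give about 3000 nM, estimated within 500 nM to 20000 nM.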

Compound 3, half-maximal inhibitory concentration: 2600 nM
Estimate against measurement, compound 3: 1.2-fold (0.06 log units) above, within the range that was stated.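

Putting 4-(2-hydroxyethyl)piperidin-1-yl in place of (3-aminopropyl)amino on the carbonyl carbon gives a 1.6-fold lower number from compound 1 to compound 3 (0.21 log units; within the scatter) in this assay and so leaves the read-out indistinguishable. This position therefore carries a group with a six-membered non-aromatic ring as well as an open chain ending in an amine, with no measurable difference between them. Nothing available explains this result.

Compound 2 has no number, so steps to it cannot be read. From the compounds shown here alone, whether a carboxylic acid or a longer chain on this carbonyl carbon would shift the value beyond the scatter remains open.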